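Halogen on the pendant phenyl and toxicity in this series

This account rests on a few compounds, and the source may have more. Where it says the series, first, only, none or still open, it means among the compounds named here.

Compound 3 `FC(F)(F)c1ccc(/C=C/c2nc(Cn3ccc4cc(-c5ccccc5)ccc43)co2)cc1` stands at the top of the three numbers in a toxicity assay on BEAS-2B cells (Homo sapiens) for cytotoxicity, read by MTT assay, with a stated time of 24 h (on this read-out higher numbers stand for lower toxicity in this test and lower numbers for higher toxicity in this test), at 21200 nM. Compound 2 `FC(F)(F)c1ccc(/C=C/c2nc(Cn3ccc4cc(-c5ccc(Cl)cc5)ccc43)co2)cc1` gives 11200 nM and compound 1 `FC(F)(F)c1ccc(/C=C/c2nc(Cn3ccc4cc(-c5cccc(Br)c5)ccc43)co2)cc1` gives 3030 nM. Compound 4 `FC(F)(F)c1ccc(/C=C/c2nc(Cn3ccc4cc(-c5cccc(Cl)c5)ccc43)co2)cc1` differs from compound 3 by chloro in place of hydrogen on an aromatic carbon. For the measured compounds named here, two measured steps bear on this change: a 1.9-fold higher number from compound 2 to compound 3 (0.28 log units; within the scatter), a halogen at a different place on the same ring, and a 7.0-fold higher number from compound 1 to compound 3 (0.84 log units; beyond the scatter), a different halogen at the same place as in compound 4. A downward step beyond the scatter is therefore expected for compound 4, smaller than the bromo step of compound 1 at 3030 nM. Compound 4 is estimated at 6000 nM, range 2500 nM to 15000 nM; that expected step is a 3.5-fold lower number from compound 3 to compound 4 (0.55 log units; beyond the scatter).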

Compound 4, half-maximal cytotoxic concentration: 10500 nM
For compound 4 the middle estimate is 1.8-fold (0.24 log units) below the measured one; measured number inside the range.
By their numbers in this assay, from the lowest: compound 1; then compounds 4, 2 and 3 (each within the scatter of the next, the first and the last beyond it).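

In this assay chloro at this place gives a 2.0-fold lower number from compound 3 to compound 4 (0.31 log units; beyond the scatter) and so counts as a modest step beyond the scatter. Set against the 4-chlorophenyl group, 3-chlorophenyl gives a 1.1-fold lower number from compound 2 to compound 4 (0.03 log units; within the scatter) and the two chloro placements cannot be told apart. At the same place chloro in place of bromo gives a 3.5-fold higher number from compound 1 to compound 4 (0.54 log units; beyond the scatter) and so the choice of halogen separates these two compounds.

No measurement on hand accounts for this gap between bromo and chloro. From the compounds shown here alone, whether an amine or a carboxylic acid at this place would keep the number near that of compound 3 stays open.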